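Replacing the nitrooxy-bearing chain of compound 2 with isopropyl

This account rests on a few compounds, and the source may have more. Where it says the series, first, only, none or still open, it means among the compounds named here.

The three measured compounds share one core and differ only in the group carried on an oxygen next to a carbonyl group. Compound 1 `CC1=C(C(=O)OCCO[N+](=O)[O-])C(c2cccc3nonc23)C([N+](=O)[O-])=C(C)C1` gives 31100 nM in a functional assay (cardiac atrium) for agonist activity, with Cavia porcellus as the target; a lower number here means that less compound is needed, a higher number that more compound is needed for the effect. Compound 2 `CC1=C(C(=O)OCCCCO[N+](=O)[O-])C(c2cccc3nonc23)C([N+](=O)[O-])=C(C)C1` gives 4030 nM, and compound 3 `CC1=C(C(=O)O[C@@H](C)CO[N+](=O)[O-])[C@@H](c2cccc3nonc23)C([N+](=O)[O-])=C(C)C1` gives 33700 nM. Compound 2 therefore stands lowest of the three numbers, with compound 1 the nearest and compound 3 the furthest, both beyond the scatter.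

Compound 4 `CC1=C(C(=O)OC(C)C)C(c2cccc3nonc23)C([N+](=O)[O-])=C(C)C1` has not been measured. Its difference from compound 2 is isopropyl in place of 4-(nitrooxy)butyl on an oxygen next to a carbonyl group. Among the compounds with values here, the only measured step that touches this part of the molecule is a 7.7-fold lower number from compound 1 to compound 2 (0.89 log units; beyond the scatter), where lengthening the nitrooxy-bearing chain gave the lower number. Within the data shown here, compound 4 goes the other way: the chain is shortened, and the nitrooxy group is gone altogether, a change no measured pair covers. Compound 3, with its own short nitrooxy-bearing chain, also sits at a high number, while compound 1 shows what a shorter chain did. Going by these compounds, on that basis a higher number is expected for compound 4, of a size about like a 5.0-fold higher number from compound 2 to compound 4 (0.70 log units; beyond the scatter), though with wide uncertainty because the loss of the nitrooxy group is untested. Compound 4 is estimated at 20000 nM, within the range 4000 nM to 90000 nM.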

Compound 4, half-maximal effective concentration: 9400 nM
For compound 4 the middle estimate is 2.1-fold (0.33 log units) above the measured one; measured number inside the range.
By their numbers in this assay, from the lowest: compound 2; then compound 4; then compounds 1 and 3 (each within the scatter of the next).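

The nitrooxy group is not required at this position for a number below that of compound 1: in this assay, isopropyl on an oxygen next to a carbonyl group gives a 3.3-fold lower number from compound 1 to compound 4 (0.52 log units; beyond the scatter) and replaces 2-(nitrooxy)ethyl with a group that has no nitrogen or oxygen atoms. The same replacement of 4-(nitrooxy)butyl does cost something (a 2.3-fold higher number from compound 2 to compound 4 (0.37 log units; beyond the scatter)), so compound 4 falls between the two compounds with straight nitrooxy-bearing chains, and the presence of a nitrooxy group alone does not set the order among compound 1, compound 2 and compound 4. Nothing available explains why isopropyl falls at this place in the order.

The step from compound 2 to compound 4 changes both the length of the chain and the presence of the nitrooxy group, so the share of each in the difference stays unresolved, and a plain butyl group on the same oxygen would be needed to separate them. Also open, going by these compounds, is how this position would respond to an amine or a carboxylic acid at the end of the chain, or to a chain longer than 4-(nitrooxy)butyl.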